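Fluoro for ethoxy on the anilide: compound 3 to compound 4

The compounds below may be only part of what the source reports. "The series", "measured", "known", "first", "only" and "open" are said of these compounds alone.

Measured compounds:
compound 1 `O=C(/C=C/c1coc2cc(O)ccc2c1=O)NCc1ccc(F)cc1`, > 100000 nM
compound 2 `COc1ccc(CNC(=O)/C=C/c2coc3cc(OC)ccc3c2=O)cc1`, 7570 nM
compound 3 `CCOc1ccc(NC(=O)/C=C/c2coc3cc(OC)ccc3c2=O)cc1`, 3230 nM

In a functional assay on Huh-7 cells (Homo sapiens) for inhibition, read by MTT assay, with a stated time of 48 h (a higher number here means a weaker inhibitor, a lower number a stronger inhibitor), compound 1 gives > 100000 nM, which is a limit of the assay and not a number (the limit of > 100000 nM in this assay, at which 1 of the 3 values shown sits). In this assay compound 2 gives 7570 nM and compound 3 gives 3230 nM. Compound 3 therefore holds the lowest of the two numbers shown; the one measured single-place step, a 2.3-fold lower number from compound 2 to compound 3 (0.37 log units; beyond the scatter), separates it from compound 2.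

Compound 4 `COc1ccc2c(=O)c(/C=C/C(=O)Nc3ccc(F)cc3)coc2c1` is not yet measured. Its difference from compound 3 is fluoro in place of ethoxy on an aromatic carbon. No measured step matches this change: the only step shown concerns the swap of 4-methoxybenzyl for 4-ethoxyphenyl, and compound 1, the sole compound carrying a fluoro group, differs from compound 4 in more than one place and sits at a limit. The step from compound 3 to compound 4 can thus only be expected to be modest in either direction, with a loss of potency held somewhat more likely on the removal of the ethoxy group, so the expected step is a 1.9-fold higher number from compound 3 to compound 4 (0.27 log units; within the scatter). In this assay compound 4 is accordingly estimated at 6000 nM, with a range from 2000 nM to 25000 nM.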

Compound 4, half-maximal inhibitory concentration: 33900 nM
For compound 4 the middle estimate is 5.7-fold (0.75 log units) below the measured one; the whole stated range lies below it.
By their numbers in this assay, from the lowest: compound 3; then compound 2; then compound 4. At a limit, above all of these: compound 1.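

In this assay, for the compounds shown here, the aromatic carbon para to a large group is sensitive to its substituent: fluoro in place of ethoxy, with the rest of compound 3 unchanged, gives the only large step (a 10-fold higher number from compound 3 to compound 4 (1.02 log units; beyond the scatter)). The aryl group on the amide-type nitrogen does not set the direction on its own, since 4-ethoxyphenyl in place of 4-methoxybenzyl gives a gain (a 2.3-fold lower number from compound 2 to compound 3 (0.37 log units; beyond the scatter)), whereas 4-fluorophenyl in its place gives a loss (a 4.5-fold higher number from compound 2 to compound 4 (0.65 log units; beyond the scatter)). Among compounds 2, 3 and 4, the substituent on that ring carbon therefore decides the sign of the change, but nothing shown here accounts for the size of the loss.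

Open, going by these compounds, is whether methoxy, a longer propoxy chain, an amine or a carboxylic acid on the same ring carbon would stay near compound 3 or fall toward compound 4. On these data alone, compound 1 gives > 100000 nM, which is a limit of the assay and not a number, so the effect of fluoro on the 4-substituted benzyl amides also stays open.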